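This account rests on a few compounds, and the source may have more. Where it says the series, first, only, none or still open, it means among the compounds named here.

Working notes on the series. Within the data shown here, compound 2 `COc1cc(-c2nn(-c3cccc(NC(=O)c4ccc(Cl)c(C(F)(F)F)c4)c3)cc2-c2ccncc2)ccc1Cl` gives 1290 nM in a functional assay on PC-3 cells (Homo sapiens) for inhibition, read by sulforhodamine B assay, with a stated time of 48 h (a lower number here means a stronger inhibitor, a higher number a weaker inhibitor), the highest number of the two measured; the nearest measured compound is compound 1 `COc1cc(-c2nn(-c3cccc(NC(=O)Nc4cccc(C(F)(F)F)c4)c3)cc2-c2ccncc2)ccc1Cl`, which in this assay gives 370 nM, and the only measured step is a 3.5-fold higher number from compound 1 to compound 2 (0.54 log units; beyond the scatter). Compound 3 `COc1cc(-c2nn(-c3cccc(NC(=O)c4ccccc4)c3)cc2-c2ccncc2)ccc1Cl` is not yet measured. It differs from compound 2 by phenyl in place of 4-chloro-3-(trifluoromethyl)phenyl on a carbonyl carbon. Among the measured compounds shown here, the measured step changes the group on the carbonyl carbon from an arylamino group to a substituted aryl group, so it alters a different part of the molecule and does not bear directly on stripping the chlorine and trifluoromethyl from the aryl ring; it shows only that changes at this position are felt in this assay to a modest degree. For the measured compounds named here, no measured pair tells what removing the halogenated substituents does. The phenyl of compound 3 keeps the amide but drops the halogen and trifluoromethyl groups, so a further weakening beyond the scatter is expected, tentatively of the size a 2.7-fold higher number from compound 2 to compound 3 (0.43 log units; beyond the scatter). Compound 3 is therefore estimated at 3500 nM in this assay, with a range from 1000 nM to 12000 nM.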

Compound 3, half-maximal inhibitory concentration: 430 nM
Beside the measured number, compound 3's estimate is 8.1-fold (0.91 log units) above it; measured number below the stated range.
By their numbers in this assay, from the lowest: compounds 1 and 3 (each within the scatter of the next); then compound 2.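

In this assay, among these compounds, the step of a 3.0-fold lower number from compound 2 to compound 3 (0.48 log units; beyond the scatter) reads directly what the chlorine and trifluoromethyl contribute on the ring at the carbonyl carbon: stripping them does not weaken the compound, and the substituted ring is the one with the higher number. The step of a 1.2-fold higher number from compound 1 to compound 3 (0.07 log units; within the scatter) puts the plain phenyl amide level with the (3-(trifluoromethyl)phenyl)amino compound, so replacing that arylamino group with an aryl group does not on its own carry a penalty in this series, and the higher number of compound 2 goes with its 4-chloro-3-(trifluoromethyl)phenyl group. No measurement at hand accounts for this difference.

The compounds shown do not separate the two substituents, so a phenyl carrying only the chlorine or only the trifluoromethyl would be needed to tell whether one of them alone goes with the higher number. They also leave open whether a different group on this phenyl, such as a methoxy, an amine or a carboxylic acid, would lower the number or raise it.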